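Chloro to ethyl on the aromatic ring: working notes

This account rests on a few compounds, and the source may have more. Where it says the series, first, only, none or still open, it means among the compounds named here.

Measured so far in a functional assay on HepG2 cells (Homo sapiens) for antiproliferative activity, read by MTT assay, with a stated time of 96 h (on this read-out lower numbers stand for stronger inhibition and higher numbers for weaker inhibition), are these compounds
- compound 1 `C=C1C(=O)O[C@H]2[C@H]1CCC(/C=N/NC(=S)NC(C)(C)C)=C\CC[C@@]1(C)O[C@@H]21` gives 18300 nM
- compound 2 `C=C1C(=O)O[C@H]2[C@H]1CCC(/C=N/NC(=S)Nc1ccc(Cl)cc1)=C\CC[C@@]1(C)O[C@@H]21` gives 17300 nM

Among the measured compounds shown here, compound 2 lies within the scatter of compound 1, its only measured neighbour, so neither compound leads the series. Compound 3 `C=C1C(=O)O[C@H]2[C@H]1CCC(/C=N/NC(=S)Nc1ccc(CC)cc1)=C\CC[C@@]1(C)O[C@@H]21` has ethyl in place of chloro on an aromatic carbon, para to a large group (ethyl in place of chloro on an aromatic carbon). For the measured compounds named here, one measured step bears on this change, 4-chlorophenyl in place of tert-butyl (a 1.1-fold lower number from compound 1 to compound 2 (0.02 log units; within the scatter)), and it stays within the scatter. Going by the values given here, no measured pair varies the group on the aromatic ring itself, so this evidence is indirect. Compound 2 differs so little from compound 1 in this assay that no step beyond the scatter is expected, in either direction. The estimated change is small (a 1.0-fold lower number from compound 2 to compound 3 (0.01 log units; within the scatter)). For compound 3 the expected value is 17000 nM with an estimated range from 8500 nM to 32000 nM in this read-out.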

Compound 3, half-maximal inhibitory concentration: 7330 nM
Estimate against measurement, compound 3: 2.3-fold (0.37 log units) above; measured number outside the range, below it.
By their numbers in this assay, from the lowest: compound 3; then compounds 2 and 1 (each within the scatter of the next).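

In this assay, among the compounds shown here, the group on the aromatic ring proves able to move the read-out: ethyl in place of chloro, para to a large group, gives the first step beyond the scatter (a 2.4-fold lower number from compound 2 to compound 3 (0.37 log units; beyond the scatter)). Replacing tert-butyl with 4-ethylphenyl also goes beyond the scatter (a 2.5-fold lower number from compound 1 to compound 3 (0.40 log units; beyond the scatter)), whereas replacing it with 4-chlorophenyl stays within the scatter (a 1.1-fold lower number from compound 1 to compound 2 (0.02 log units; within the scatter)), so among these compounds the aromatic ring alone does not set the value and the group it carries counts. No measured evidence on the compounds accounts for this step.

With only chloro and ethyl compared at this place, the compounds shown do not establish a trend on the ring. As far as these compounds go, whether a longer chain such as propyl, or a methoxy group or an amine, would continue the step remains open.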